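A few compounds are considered here, and "the series" means these few. Any claim that something is new, unique, unknown or untested is made for them only; others in the source may bear on it.

Measured in an assay on isolated protein for inhibition of hexokinase-1 (Rattus norvegicus), with a stated time of 6 h, tested at 10 mM; a lower number here means less inhibition, a higher number more inhibition at the concentration tested (going by the name of the read-out): compound 1 `O=C(CI)NCCCCCC(=O)NCCCNc1ncnc2c1ncn2[C@@H]1O[C@H](COP(=O)(O)OP(=O)(O)OP(=O)(O)O)[C@@H](O)[C@H]1O`, 0%; compound 2 `O=C(CI)NCCC(=O)NCCCCCCNc1ncnc2c1ncn2[C@@H]1O[C@H](COP(=O)(O)OP(=O)(O)OP(=O)(O)O)[C@@H](O)[C@H]1O`, 0%; compound 3 `O=C(CI)NCCCC(=O)NCCCCCCNc1ncnc2c1ncn2[C@@H]1O[C@H](COP(=O)(O)OP(=O)(O)OP(=O)(O)O)[C@@H](O)[C@H]1O`, 0%.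

Among the compounds with values here, all three measured compounds sit level in this assay, so the series so far gives no step that leaves the scatter. Compound 1 and compound 2 share the same atoms joined differently; the difference between the two cores is not broken down here. Compound 2 and compound 3 differ by one change, ((((iodomethyl)carbonyl)amino)methyl in place of ((iodomethyl)carbonyl)amino on a saturated chain carbon, two bonds along the chain from a carbonyl carbon), and that change gives no change at the digits printed from compound 2 to compound 3 (within the scatter).

Compound 4 `O=C(CI)NCCCCCCC(=O)NCCCNc1ncnc2c1ncn2[C@@H]1O[C@H](COP(=O)(O)OP(=O)(O)OP(=O)(O)O)[C@@H](O)[C@H]1O` is not yet measured. It stands to compound 1 as compound 3 stands to compound 2: the same kind of change, ((((iodomethyl)carbonyl)amino)methyl in place of ((iodomethyl)carbonyl)amino on a saturated chain carbon, five bonds along the chain from a carbonyl carbon), though the place differs, two bonds along the chain from a carbonyl carbon in the measured pair against five bonds along the chain from a carbonyl carbon here. The expectation for compound 4 is a step of no change at the digits printed from compound 1 to compound 4 (within the scatter), resting on the flat step no change at the digits printed from compound 2 to compound 3 (within the scatter) and on compound 1 giving 0%. Compound 4 is thus estimated at 0%, expected between -5% and 10%.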

Compound 4, a percentage reported as inhibition, at one concentration (the size of the read-out at that concentration, not a potency): 0%
The estimate for compound 4 equals the measured number at the digits printed; the range from low to high includes it.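

In this assay, (((iodomethyl)carbonyl)amino)methyl in place of ((iodomethyl)carbonyl)amino, on a saturated chain carbon five bonds along the chain from a carbonyl carbon, gives no change at the digits printed from compound 1 to compound 4 (within the scatter). Set beside the earlier pair, the change reads the same on both cores: the same change on two cores in this assay, no change at the digits printed (within the scatter) from compound 2 to compound 3 and no change at the digits printed (within the scatter) from compound 1 to compound 4, 0 percentage points apart, within the scatter of two such steps

This agreement is only between two flat steps at one tested concentration, with compound 4 at 0%, so it does not show how the change would carry to a core with measurable inhibition in this assay.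

The compounds shown leave open whether a longer chain would give any reading other than these in this assay. Also open, as far as these compounds go, is whether an amine or a carboxylic acid in place of ((iodomethyl)carbonyl)amino would read differently from compound 1 at 0%.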